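Filling the ring amine of compound 1: first expectation

The source may report more compounds than this note shows. Statements on the series, on what has been measured and on what is new or still open speak of the compounds shown alone.

Compound 1 `CCCCNc1nc(N)nc2c1CNCC2` carries only a hydrogen on the amine nitrogen in the ring. Within the data shown here, in an assay on HEK293 cells for agonist activity at Toll-like receptor 8 (Homo sapiens), read by a luciferase reporter, with a stated time of 6 h (on this read-out higher numbers stand for an effect only at larger amounts of compound and lower numbers for an effect already at smaller amounts), compound 1 gives 7.2 uM, the highest of the two numbers measured so far. Compound 2 `CCCCNc1nc(N)nc2c1CN(Cc1ccc(C(C)(C)C)cc1)CC2` carries a substituent on that same nitrogen, and in this assay compound 2 gives 0.66 uM; the gap between compound 1 and compound 2 lies well beyond the scatter, so occupying this nitrogen has gone with an effect at smaller amounts in the one case at hand.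

Compound 3 `CCCCNc1nc(N)nc2c1CN(Cc1ccncc1)CC2` is the next candidate and has not yet been measured. Its change from compound 1 is (pyridin-4-yl)methyl in place of hydrogen on an amine nitrogen in a ring. Among the measured compounds shown here, only the pair compound 1 and compound 2 speaks to this position, and compound 3 carries a different group there, so the evidence is thin.

Compound 3 is expected to give about 2 uM in this assay, with a range from 0.7 uM to 6 uM. The step expected a 3.6-fold lower number from compound 1 to compound 3 (0.56 log units; beyond the scatter) points toward lower numbers and beyond the scatter, because compound 2 gives 0.66 uM after a change at the same nitrogen, though a smaller move than that one is assumed.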

Compound 3, minimum effective concentration: 0.29 uM
For compound 3 the middle estimate is 6.9-fold (0.84 log units) above the measured one; the measured number lies below the stated range.
By their numbers in this assay, from the lowest: compound 3; then compound 2; then compound 1.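

In this assay the change to (pyridin-4-yl)methyl in place of hydrogen on the amine nitrogen in the ring gives a 25-fold lower number from compound 1 to compound 3 (1.39 log units; beyond the scatter) and so adds a second, quite different substituent at this nitrogen that goes with an effect at smaller amounts. Among these compounds, the move therefore no longer rests on the single group of compound 2: compound 3 gives 0.29 uM with a six-membered aromatic ring holding one hetero atom, while compound 2 gives 0.66 uM with its own substituted benzyl group. No measurement at hand accounts for the size of this step.

A plain benzyl group on the same amine nitrogen would show whether the ring nitrogen of the (pyridin-4-yl)methyl group counts for anything in the step, and the isomeric (pyridin-2-yl)methyl group would test where that ring nitrogen may stand. Also open, as far as these compounds go, is how a small methyl group, or an acyl group that places a carbonyl directly on this amine nitrogen, would read in this assay on the core of compound 1.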